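The compounds below may be only part of what the source reports. "The series", "measured", "known", "first", "only" and "open" are said of these compounds alone.

Within the data shown here, in a functional assay on A549 cells (Homo sapiens) for inhibition, read by sulforhodamine B assay, with a stated time of 48 h (a higher number here means a weaker inhibitor of growth, a lower number a stronger inhibitor of growth), compound 2 `COC1=C(OC)[C@H](OC(C)=O)[C@H](C/C=C(\C)CC/C=C(\C)C[C@H](O)/C=C(\C)CO)[C@@H](C)C1=O` gives 29000 nM, the higher of the two numbers measured so far. Compound 1 `COC1=C(OC)[C@H](O)[C@H](C/C=C(\C)CC/C=C(\C)C[C@@H]2C[C@@H](C)C(=O)O2)[C@@H](C)C1=O` gives 14100 nM in this assay, and the gap between these two values lies beyond the usual scatter. Compound 3 `COC1=C(OC)[C@H](OC(C)=O)[C@H](C/C=C(\C)CC/C=C(\C)C[C@@H]2C[C@@H](C)C(=O)O2)[C@@H](C)C1=O` has not yet been measured in this assay. It differs from compound 2 in one place: a group of 7 heavy atoms (5 carbon, 2 oxygen; one five-membered non-aromatic ring with 1 hetero atom) in place of a group of 7 heavy atoms (5 carbon, 2 oxygen; no ring), on a saturated chain carbon bound to a double-bonded chain carbon. The group that enters in compound 3 is the same group that compound 1 carries at that place, while compound 3 keeps everything else from compound 2. Since compound 1 carrying this group gave 14100 nM, compound 3 is expected to shift toward a lower number, by a step of a 1.7-fold lower number from compound 2 to compound 3 (0.23 log units; within the scatter) of modest size, close to the edge of the scatter. Compound 3 is accordingly estimated at 17000 nM, with a range from 6000 nM to 45000 nM.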

Compound 3, concentration for 50% growth inhibition: 11300 nM
Compound 3: the middle estimate sits 1.5-fold (0.18 log units) above what was measured, within the range that was stated.
By their numbers in this assay, from the lowest: compounds 3 and 1 (each within the scatter of the next); then compound 2.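

In this assay, the step of a 2.6-fold lower number from compound 2 to compound 3 (0.41 log units; beyond the scatter) shows that, with the acetyl kept, exchanging the ring-free group for the group with one five-membered non-aromatic ring with 1 hetero atom, on a saturated chain carbon bound to a double-bonded chain carbon, changes the number beyond the scatter. The step of a 1.2-fold lower number from compound 1 to compound 3 (0.10 log units; within the scatter), with acetyl in place of hydrogen on an oxygen on a saturated carbon, stays within the scatter, so this acetyl change does not separate the two compounds when the ring group is present. Nothing available explains either result.

As far as these compounds go, it remains open whether the ring itself accounts for the step, or whether a carboxylic acid or an amine at this place would behave alike. The compounds shown also cannot tell whether the acetyl change would remain within the scatter with the ring-free group in place.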